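The compounds below may be only part of what the source reports. "The series", "measured", "known", "first", "only" and "open" are said of these compounds alone.

Compound 2, `Cc1ccc(-c2nn(CCCCN3CCN(c4cccc(Cl)c4)CC3)c(=O)c3ccccc23)cc1`, is the weaker of the two compounds measured in an assay on Cerebral cortex for displacement of a labelled ligand from Adrenergic receptor alpha-1 (Rattus norvegicus); a higher number here means a weaker inhibitor, a lower number a stronger inhibitor: compound 2 gives 12.4 nM, whereas compound 1, `Cc1ccc(-c2nn(CCCCN3CCN(c4ccccc4OC(C)C)CC3)c(=O)c3ccccc23)cc1`, gives 1.07 nM. For the measured compounds named here, the only step recorded, a 12-fold higher number from compound 1 to compound 2 (1.06 log units; beyond the scatter), concerns the aromatic ring on the amine nitrogen of the piperazine as a whole and is large.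

Compound 3, `Cc1ccc(-c2nn(CCCCN3CCN(c4cccc(C(F)(F)F)c4)CC3)c(=O)c3ccccc23)cc1`, differs from compound 2 in a smaller way: trifluoromethyl in place of chloro on an aromatic carbon. Going by the values given here, no measured step in this assay exchanges one substituent for another on that ring, so the one step recorded does not bear on this change directly, and nothing in the numbers gives a direction for it. Compound 3 is therefore expected to stay close to compound 2 in this assay, with a step of a 1.0-fold lower number from compound 2 to compound 3 (0.01 log units; within the scatter) that need not exceed the scatter. The estimate for compound 3 is 12 nM, within a range from 4 nM to 40 nM.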

Compound 3, inhibition constant: 112 nM
Compound 3: the middle estimate sits 9.3-fold (0.97 log units) below what was measured; measured number outside the range, above it.
By their numbers in this assay, from the lowest: compound 1; then compound 2; then compound 3.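

In this assay the substituent on this aromatic carbon matters on its own: trifluoromethyl in place of chloro gives a 9.0-fold higher number from compound 2 to compound 3 (0.96 log units; beyond the scatter) and so moves the number beyond the scatter with the rest of the molecule unchanged. The exchange of the whole aromatic ring also grows, as 3-(trifluoromethyl)phenyl in place of 2-isopropoxyphenyl gives a 100-fold higher number from compound 1 to compound 3 (2.02 log units; beyond the scatter) and leaves compound 3 the weakest of the three. No measurement at hand accounts for either step.

As far as these compounds go, with only chloro and trifluoromethyl compared here, it remains open whether a fluoro, methoxy or nitrile group on this carbon would fall nearer compound 2 or compound 3. From the compounds shown here alone, it is also open whether the exchange of chloro for trifluoromethyl would keep its size with a shorter chain joining the core to the piperazine.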